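Ortho-Substituted Aryl Triazoles on a Spirooxindole Scaffold

A few compounds are considered here, and "the series" means these few. Any claim that something is new, unique, unknown or untested is made for them only; others in the source may bear on it.

Compound 1 `CCc1ccccc1-n1nncc1CN1C(=O)C2(C(C#N)=C(N)Oc3c(N)cc4nc5ccccc5nc4c32)c2ccccc21`: 22900 nM
Compound 2 `CC(=O)Nc1ccc(-n2nncc2CN2C(=O)C3(C(C#N)=C(N)Oc4c(N)cc5nc6ccccc6nc5c43)c3ccccc32)cc1`: > 50000 nM
Compound 3 `CCOc1ccc(-n2nncc2CN2C(=O)C3(C(C#N)=C(N)Oc4c(N)cc5nc6ccccc6nc5c43)c3ccccc32)cc1`: > 50000 nM

Three compounds share one core and differ only in the aryl group on the triazole nitrogen. In an ADME assay on L02 cells (Homo sapiens) for antiproliferative activity, read by MTT assay, with a stated time of 48 h (a lower number here means a stronger inhibitor, a higher number a weaker inhibitor), compound 1 gives 22900 nM. Compound 2 gives only a limit of the assay, > 50000 nM. Compound 3 likewise gives only a limit, > 50000 nM. Two of the three values therefore sit at the limit of > 50000 nM in this assay, at which 2 of the 3 values shown sit, which leaves compound 3 at the weak end of what can be read: the step of an at least 2.1-fold higher number from compound 1 to compound 3 (0.33 log units; beyond the scatter) is a weakening, and the step that the two limits leave unreadable from compound 2 to compound 3 cannot be read.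

Compound 4 `CCc1cccc(C)c1-n1nncc1CN1C(=O)C2(C(C#N)=C(N)Oc3c(N)cc4nc5ccccc5nc4c32)c2ccccc21` carries the change (2-ethyl-6-methylphenyl in place of 4-ethoxyphenyl on an aromatic nitrogen). The measured steps that bear on it are an at least 2.1-fold higher number from compound 1 to compound 2 (0.33 log units; beyond the scatter) and an at least 2.1-fold higher number from compound 1 to compound 3 (0.33 log units; beyond the scatter), both of which show that moving from a 2-ethylphenyl to a para-substituted phenyl bearing an acceptor weakened the inhibition beyond the scatter. Compound 4 returns to an ortho-alkylated phenyl with no acceptor, closer to compound 1 than to compound 3, so a return toward the value of compound 1 is expected, meaning a step of an at least 2.0-fold lower number from compound 3 to compound 4 (0.30 log units; that floor lies within the scatter) of at least modest size downward. Compound 4 is therefore estimated at 25000 nM, within 9000 nM to 60000 nM.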

Compound 4, half-maximal inhibitory concentration: > 50000 nM
Compound 4: a limit, no number; the forecaster's own chance of this, stated with the estimate: 35%; middle value at least 2.0-fold (0.30 log units) away from the limit.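

Adding one methyl to the 2-ethylphenyl group gives an at least 2.1-fold higher number from compound 1 to compound 4 (0.33 log units; beyond the scatter) in this assay, so this small change on the aryl group is enough to lose the readable value. The earlier steps shown here had replaced 2-ethylphenyl with 4-acetamidophenyl or 4-ethoxyphenyl, each a different aryl group with a hydrogen-bond acceptor, whereas 2-ethyl-6-methylphenyl keeps the ethyl group and has 0 hydrogen-bond acceptors, which shows that an acceptor on the aryl group is not required for a compound to reach the limit. Compound 1 is now the only one of the four with a readable number, and the steps among compound 2, compound 3 and compound 4 cannot be read, since all three stand at one limit of the assay: the limit of > 50000 nM in this assay, at which 3 of the 4 values shown sit.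

Going by these compounds, how far compound 4 lies beyond that limit remains unknown, so the full size of the loss from the added methyl stays open. On these data alone, it is also open whether a fluorine, a chlorine or a methoxy group in place of that methyl would keep a readable value.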